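A few compounds are considered here, and "the series" means these few. Any claim that something is new, unique, unknown or untested is made for them only; others in the source may bear on it.

Series notes. Compound 1, `CN1CC(NC(=O)c2cc(-c3ccc(NS(=O)(=O)c4cccc(Cl)c4Cl)cc3)nc3[nH]ncc23)C1`, and compound 2, `CCOc1nc(-c2ccc(NS(=O)(=O)c3cc(Cl)ccc3F)cc2)nc2[nH]nc(C)c12`, have been measured in an assay for inhibition of serine/threonine-protein kinase Sgk1 (Homo sapiens), with stated times of 30 min and 60 min, in the presence of a further agent that is not named here; a higher number here means a weaker inhibitor, a lower number a stronger inhibitor. For compound 1 the result in this assay is a limit of the assay, < 1 nM (the limit of < 1 nM in this assay, at which 1 of the 2 values shown sits). Compound 2 gives 183 nM in this assay, the only number shown for the series. Among the compounds with values here, since only one number is available, no measured step between two numbers can be formed. Compound 3, `Cc1n[nH]c2nc(-c3ccc(NS(=O)(=O)c4cc(Cl)ccc4F)cc3)nc(OC3CC(C)(C)NC(C)(C)C3)c12`, is not yet measured. It differs from compound 2 in one place: 2,2,6,6-tetramethylpiperidin-4-yl in place of ethyl on an oxygen on an aromatic ring, the difference cut one bond further out reading ethoxy to (2,2,6,6-tetramethylpiperidin-4-yl)oxy. Within the data shown here, no measured step covers such a change, so the expectation rests only on compound 2 at 183 nM and is uncertain. In this assay a shift toward a stronger inhibitor is expected, a 4.6-fold lower number from compound 2 to compound 3 (0.66 log units; beyond the scatter), beyond the scatter but moderate. Compound 3 is estimated at 40 nM in this assay, within a range from 8 nM to 200 nM.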

Compound 3, half-maximal inhibitory concentration: 4 nM
Beside the measured number, compound 3's estimate is 10-fold (1.00 log units) above it; measured number below the stated range.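

In this assay, within the data shown here, the exchange of ethyl for 2,2,6,6-tetramethylpiperidin-4-yl on an oxygen on an aromatic ring gives a 46-fold lower number from compound 2 to compound 3 (1.66 log units; beyond the scatter) and is the first measured step. This position therefore accepts a six-membered non-aromatic ring carrying a hydrogen-bond donor in place of ethyl, which carries none, and the number falls rather than rises. Nothing measured here says which part of this difference accounts for the step.

Still open, as far as these compounds go, is whether the ring or its nitrogen carries the step: a cyclohexyl group would keep the ring without the nitrogen, and a plain piperidin-4-yl would keep the nitrogen without the methyl groups. Also open, from the compounds shown here alone, is whether a longer chain ending in an amine would serve at this oxygen as well.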